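From Dimethylpiperidine to Methylpiperazine: A Cytotoxicity Step

This account rests on a few compounds, and the source may have more. Where it says the series, first, only, none or still open, it means among the compounds named here.

Compound 1 `N#Cc1ccc(Nc2nc(Oc3ccnc4ccccc34)nc(N3CCN(c4ccccc4Cl)CC3)n2)cc1C(F)(F)F`, compound 2 `CC(=O)N1CCN(c2nc(Nc3ccc(C#N)c(C(F)(F)F)c3)nc(Oc3ccnc4ccccc34)n2)CC1` and compound 3 `CC1CC(C)CN(c2nc(Nc3ccc(C#N)c(C(F)(F)F)c3)nc(Oc3ccnc4ccccc34)n2)C1` were each tested in a functional assay on DU-145 cells (Homo sapiens) for cytotoxicity, read by sulforhodamine B assay, with a stated time of 48 h; a higher number here means that more compound is tolerated, a lower number that less compound is tolerated. Compound 1 reaches only the limit of > 100000 nM, which is a bound of the assay and not a number. Compound 2 likewise sits at the limit of > 100000 nM. Compound 3 also stops at the limit of > 100000 nM. Both measured steps, a step that the two limits leave unreadable from compound 1 to compound 2 and a step that the two limits leave unreadable from compound 2 to compound 3, are therefore unreadable, and the limit of > 100000 nM in this assay, at which 3 of the 3 values shown sit, is all the measurements state. Compound 3 thus stands at the same limit as the others, with no numbered value to set it apart.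

Compound 4 `CN1CCN(c2nc(Nc3ccc(C#N)c(C(F)(F)F)c3)nc(Oc3ccnc4ccccc34)n2)CC1` differs from compound 3 by 4-methylpiperazin-1-yl in place of 3,5-dimethylpiperidin-1-yl on an aromatic carbon. Neither measured step bears readably on this change, and the nearest one, a step that the two limits leave unreadable from compound 2 to compound 3, which also exchanges the ring on the same aromatic carbon, gives no size either. No direction can be read, so the expectation is that compound 4 stays at the limit. Compound 4 is estimated at 100000 nM, within 30000 nM to 300000 nM, with the expected step of a number no higher from compound 3 to compound 4 (the limit leaves the size open) being none beyond the scatter.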

Compound 4, concentration lethal to 50% of the cells: > 100000 nM
Compound 4 was reported as a limit (the forecaster's own chance of this, stated with the estimate: 85%); the middle value lies on the limit itself.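

Going by these compounds alone, no step from compound 1, compound 2 or compound 3 to compound 4 can be read, and all four stop at one assay limit rather than a number: the limit of > 100000 nM in this assay, at which 4 of the 4 values shown sit. The compounds shown leave open whether any of these exchanged groups changes cytotoxicity at all.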